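Exchanging an Aryl Group Across Two Chain Lengths

The compounds below may be only part of what the source reports. "The series", "measured", "known", "first", "only" and "open" are said of these compounds alone.

Of the compounds shown here, three built on one shared core have been tested in a functional assay on MCF7 cells (Homo sapiens) for inhibition, read by MTT assay; on this read-out higher numbers stand for weaker inhibition and lower numbers for stronger inhibition. Compound 2, `CCCCCCCCn1cc(/C=C/C(=O)c2ccc(NC(=O)CN3CCN(c4ccc([N+](=O)[O-])cc4)CC3)cc2)nn1`, gives 49100 nM there. Compound 1, `CCCCCCCCn1cc(/C=C/C(=O)c2ccc(NC(=O)CN3CCN(c4ccccc4F)CC3)cc2)nn1`, differs from compound 2 by 2-fluorophenyl in place of 4-nitrophenyl on an amine nitrogen in a ring, and in this assay compound 1 gives 68600 nM, a step of a 1.4-fold higher number from compound 2 to compound 1 (0.15 log units; within the scatter). Compound 3, `CCCCCCCCCCn1cc(/C=C/C(=O)c2ccc(NC(=O)CN3CCN(c4ccc([N+](=O)[O-])cc4)CC3)cc2)nn1`, differs from compound 2 by ethyl in place of hydrogen on a saturated chain carbon, eight bonds along the chain from an aromatic nitrogen, and in this assay compound 3 gives 44400 nM, a step of a 1.1-fold lower number from compound 2 to compound 3 (0.04 log units; within the scatter). All three numbers lie within the usual scatter of one another, so none of them can be set apart from the rest.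

Compound 4, `CCCCCCCCCCn1cc(/C=C/C(=O)c2ccc(NC(=O)CN3CCN(c4ccccc4F)CC3)cc2)nn1`, has not yet been measured in this assay. It differs from compound 3 by 2-fluorophenyl in place of 4-nitrophenyl on an amine nitrogen in a ring. The place of this change is described in exactly the same words as for the change from compound 2 to compound 1, so it is the same change, now carried out on the core of compound 3 rather than on that of compound 2. The step from compound 3 to compound 4 in this assay is expected to be about a 1.4-fold higher number from compound 3 to compound 4 (0.15 log units; within the scatter), set beside the earlier 1.4-fold higher number from compound 2 to compound 1 (0.15 log units; within the scatter), because the same change gave a 1.4-fold higher number from compound 2 to compound 1 (0.15 log units; within the scatter) on the shorter chain. Compound 4 is therefore estimated at 62000 nM in this assay, with an expected range from 30000 nM to 130000 nM.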

Compound 4, half-maximal inhibitory concentration: 40400 nM
Compound 4: middle estimate off by 1.5-fold (0.19 log units), on the high side; the range from low to high includes it.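

In this assay, for the compounds shown here, exchanging 4-nitrophenyl for 2-fluorophenyl on the longer chain gives a 1.1-fold lower number from compound 3 to compound 4 (0.04 log units; within the scatter), and this step agrees with the one seen for the same exchange on the shorter chain: the same change on two cores in this assay, a 1.4-fold higher number (0.15 log units; within the scatter) from compound 2 to compound 1 and a 1.1-fold lower number (0.04 log units; within the scatter) from compound 3 to compound 4, 1.5-fold (0.19 log units) apart, within the scatter of two such steps Lengthening the chain, read this time with 2-fluorophenyl in place, gives a 1.7-fold lower number from compound 1 to compound 4 (0.23 log units; within the scatter), and this step likewise agrees with its earlier counterpart: the same change on two cores in this assay, a 1.1-fold lower number (0.04 log units; within the scatter) from compound 2 to compound 3 and a 1.7-fold lower number (0.23 log units; within the scatter) from compound 1 to compound 4, 1.5-fold (0.19 log units) apart, within the scatter of two such steps All of these steps lie within the scatter, so the agreement shows only that neither change made a readable difference on either core; it does not show that a step of real size would carry from one core to the other, and it gives neither change a direction.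

With only two aryl groups on the ring nitrogen and two chain lengths among these four compounds, it remains open whether a phenyl group without a substituent, or one bearing a methoxy group or an amine, would move the number beyond the scatter. Going by these compounds, it also remains open whether a much shorter chain, or a chain ending in a carboxylic acid, would do so, and whether any such step would then carry from one core to another.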